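The source may report more compounds than this note shows. Statements on the series, on what has been measured and on what is new or still open speak of the compounds shown alone.

Notes on the series. Compound 1 `Nc1nc(-c2ccc(Cl)o2)nc2sc(CN3CCCCCC3)cc12` and compound 2 `Nc1nc(-c2ccc(Cl)o2)nc2sc(CN3CCC(F)CC3)cc12` share one core and differ only at the amine: in an assay on CHO-K1 cells for antagonist activity at adenosine receptor A1 (Homo sapiens), read by a beta-galactosidase reporter, with stated times of 15 min and 6 h (on this read-out lower numbers stand for stronger inhibition and higher numbers for weaker inhibition), compound 1 gives 1420 nM and compound 2 gives 1080 nM. The step of a 1.3-fold lower number from compound 1 to compound 2 (0.12 log units; within the scatter) places 4-fluoropiperidin-1-yl in place of azepan-1-yl and does not separate the pair; compound 2 therefore stands alongside compound 1, with nothing to rank them.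

Compound 3 `COc1cccc(-c2nc(N)c3cc(CN4CCC(F)CC4)sc3n2)c1` keeps the amine of compound 2 and alters the aryl group instead: 3-methoxyphenyl in place of 5-chlorofuran-2-yl on an aromatic carbon. Going by the values given here, no measured step touches this position; the single step measured so far concerns the amine only and says nothing about an exchange of the 5-chlorofuran-2-yl. The direction of the change is thus unknown, and a step of a 1.2-fold higher number from compound 2 to compound 3 (0.08 log units; within the scatter) is expected only as a placeholder near the value of compound 2, with a wide band. Compound 3 is expected at 1300 nM, within 350 nM to 5000 nM.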

Compound 3, inhibition constant: 3220 nM
For compound 3 the middle estimate is 2.5-fold (0.39 log units) below the measured one; measured number inside the range.
By their numbers in this assay, from the lowest: compounds 2 and 1 (each within the scatter of the next); then compound 3.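

In this assay, the exchange of 5-chlorofuran-2-yl for 3-methoxyphenyl gives a 3.0-fold higher number from compound 2 to compound 3 (0.47 log units; beyond the scatter), with the 4-fluoropiperidin-1-yl amine held constant. This aromatic carbon, between two ring nitrogen atoms, is thus the first place in the series where a single exchange separates two compounds, and the exchange goes toward weaker inhibition. Nothing available bears on the reason for this step.

The compounds shown do not separate the effect of the ring from that of its substituent; a plain furan-2-yl or phenyl group on this carbon would address that. Going by these compounds, whether the step carries over to the azepan-1-yl amine of compound 1 also remains open.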